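The source may hold more compounds than are shown below. What is called first, only, known or untested is meant among the compounds shown, and "the series" means these compounds.

Measured compounds:
Compound 1, `CC(C)c1onc(-c2c(Cl)cccc2Cl)c1COc1ccc(-c2nc3ccc(C(=O)O)cc3n2C)cc1`, in an assay on HEK-293T cells for antagonist activity at vitamin D3 receptor (Homo sapiens), read by a luciferase reporter, with a stated time of 24 h (a higher number here means a weaker inhibitor, a lower number a stronger inhibitor), gives 7150 nM.
Compound 2, `CC(C)c1onc(-c2c(Cl)cccc2Cl)c1COc1ccc(-c2nc3cc(C(=O)O)ccc3n2C)cc1`, in this assay gives 4410 nM.

Compound 1 has the higher of the two numbers, yet its gap to compound 2 lies within the scatter of repeated measurements, so the two cannot be told apart on these figures. Among the measured compounds shown here, no step between two measured compounds is available from which the effect of any single change could be read.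

Compound 3, `CC(C)c1onc(-c2c(Cl)cccc2Cl)c1COc1ccc(-c2nc3ccc(C(=O)O)cc3n2CC(C)(C)C)cc1`, differs from compound 1 by a single change: tert-butyl in place of hydrogen on a saturated chain carbon bound to an aromatic nitrogen. Without a measured precedent for a change at this place, the expected step of a 1.4-fold lower number from compound 1 to compound 3 (0.16 log units; within the scatter) is small, with no direction that the data support beyond the scatter. Compound 3 is therefore expected to give about 5000 nM in this assay, estimated to fall between 1500 nM and 16000 nM.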

Compound 3, half-maximal inhibitory concentration: 861 nM
Beside the measured number, compound 3's estimate is 5.8-fold (0.76 log units) above it, and the stated range ends above it.
By their numbers in this assay, from the lowest: compound 3; then compounds 2 and 1 (each within the scatter of the next).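

In this assay, among the compounds shown here, tert-butyl in place of hydrogen on a saturated chain carbon bound to an aromatic nitrogen gives an 8.3-fold lower number from compound 1 to compound 3 (0.92 log units; beyond the scatter), the first single change here whose effect can be read, and it lies beyond the scatter. Since a lower number means a stronger inhibitor, this position tolerates the larger neopentyl in place of methyl, and inhibition gets stronger rather than weaker. Nothing available explains why the number falls.

From the compounds shown here alone, with only methyl and neopentyl to compare at this position, it remains open whether chain length or branching matters, and an unbranched propyl or butyl chain, or a chain ending in an amine, would help to separate these possibilities. Going by these compounds, whether the same change would give a similar step on compound 2 also remains open.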